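Switching the aryl group on a limit-bound analogue

The compounds below may be only part of what the source reports. "The series", "measured", "known", "first", "only" and "open" are said of these compounds alone.

The shared core carries an amino-pyrimidine fused to a five-membered ring, and the compounds differ in the aryl group on that ring and in the substituent on its nitrogen. Compound 1 `Nc1ncnc2c1c(-c1cccc(O)c1)cn2[C@H]1C[C@@H](CO)C1` gives 1300 nM in a functional assay on BaF3 cells (Mus musculus) for antiproliferative activity, with a stated time of 48 h; on this read-out lower numbers stand for stronger inhibition and higher numbers for weaker inhibition. Compound 2 `COC(=O)NC12CCC(n3cc(-c4ccc(Cl)c(N)c4)c4c(N)ncnc43)(CC1)CC2` gives 2600 nM in this assay; these two values lie within the usual scatter of each other. Compound 3 `CC(=O)N1CCN([C@H]2C[C@@H](n3cc(-c4cc(O)ccc4F)c4c(N)ncnc43)C2)CC1` reaches only a limit of the assay, > 10000 nM in this assay. This is the limit of > 10000 nM in this assay, at which 1 of the 3 values shown sits, so no number for compound 3 is known. Compound 4 `COc1cc(-c2cn([C@H]3C[C@@H](N4CCN(C(C)=O)CC4)C3)c3ncnc(N)c23)ccc1Cl` is not yet measured; it differs from compound 3 by 4-chloro-3-methoxyphenyl in place of 2-fluoro-5-hydroxyphenyl on an aromatic carbon. Among the measured compounds shown here, no step between measured compounds isolates this change, so the expected direction rests only on the values shown, and compound 4 is estimated at 6000 nM, between 1500 nM and 25000 nM, in this assay. The step from compound 3 to compound 4 is thus expected to be an at least 1.6-fold lower number from compound 3 to compound 4 (0.22 log units; that floor lies within the scatter), with a real chance that compound 4 also returns only a limit.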

Compound 4, half-maximal inhibitory concentration: > 10000 nM
Compound 4 gave a limit, no number (the forecaster's own chance of this, stated with the estimate: 35%); at least 1.6-fold (0.22 log units) between middle value and limit.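

Compound 3 and compound 4 both stop at a limit, so no step between them can be read: the limit of > 10000 nM in this assay, at which 2 of the 4 values shown sit.

The compounds shown leave open whether 2-fluoro-5-hydroxyphenyl or 4-chloro-3-methoxyphenyl gives the lower number in this assay, and how far beyond the limit either compound lies.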